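The source may report more compounds than this note shows. Statements on the series, on what has been measured and on what is new or still open speak of the compounds shown alone.

Measured in a functional assay on the whole organism for inhibition, with Rattus norvegicus as the target, read by paw edema, with stated times of 1 h and 3 h; on this read-out higher numbers stand for an effect only at larger amounts of compound and lower numbers for an effect already at smaller amounts:
- compound 1 `C/C(=N\OCCCC(=O)O)c1ccc(Cl)cc1`: 58 mg/kg
- compound 2 `C/C(=N\OCC(=O)N(C)C)c1ccc(Cl)cc1`: 120 mg/kg
- compound 3 `C/C(=N\OCCOC(=O)C(C)(C)C)c1ccc(Cl)cc1`: 38 mg/kg

Compound 3 lies within the usual scatter of compound 1, so the two cannot be ranked against each other. The number for compound 2 is higher than both, and beyond the scatter in each case. The next compound to be tested is compound 4 `COC(=O)OCCO/N=C(\C)c1ccc(Cl)cc1`, which keeps the shared core and changes one group of compound 3: methoxy in place of tert-butyl on a carbonyl carbon. In words, methoxy takes the place of tert-butyl on a carbonyl carbon, turning (tert-butyl)carbonyl into methoxycarbonyl.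

Among the measured compounds shown here, no measured step makes this exchange. For the measured compounds named here, the only step available, a 2.1-fold higher number from compound 1 to compound 2 (0.32 log units; beyond the scatter), puts dimethylcarbamoyl in place of 2-carboxyethyl, so it bears on the new change only indirectly. That step is modest and only just clears the scatter, which suggests that exchanging a group in this series need not move the number far. It gives no firm direction for compound 4, and a small move upward is the most that can be expected. The expected change is a 1.2-fold higher number from compound 3 to compound 4 (0.07 log units; within the scatter), which is not expected to stand clear of the scatter. For compound 4 the estimated value in this assay is 45 mg/kg, with an expected range from 20 mg/kg to 100 mg/kg.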

Compound 4, dose for half-maximal effect: 33 mg/kg
The estimate for compound 4 lay 1.4-fold (0.13 log units) above the measured number; low and high end bracket the measured number.
By their numbers in this assay, from the lowest: compounds 4, 3 and 1 (each within the scatter of the next); then compound 2.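

In this assay, methoxy can take the place of tert-butyl on the carbonyl carbon without a shift that clears the scatter, a 1.2-fold lower number from compound 3 to compound 4 (0.06 log units; within the scatter), so this exchange of an all-carbon group for one carrying oxygen does not separate the two compounds. The same read-out gives a 1.8-fold lower number from compound 1 to compound 4 (0.24 log units; within the scatter), which also stays within the scatter, whereas a 3.6-fold lower number from compound 2 to compound 4 (0.56 log units; beyond the scatter) lies beyond it, leaving compound 2, with its dimethylcarbamoyl group, as the only one of the four that stands apart from compound 4. No measurement is available that would explain why the carbonyl carbon accepts both groups or why compound 2 stands apart.

The compounds shown cover only tert-butyl and methoxy on this carbonyl carbon, so it remains open whether the number would also hold with an amine there or with a longer chain, such as butoxy. They also leave open whether the gap to compound 2 belongs to the dimethylcarbamoyl group itself or to the chain that carries it.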